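A few compounds are considered here, and "the series" means these few. Any claim that something is new, unique, unknown or untested is made for them only; others in the source may bear on it.

Two analogues of the shared core have been measured in an assay on cells for antagonist activity at transient receptor potential cation channel subfamily V member 1 (Homo sapiens), read by FLIPR and calcium flux, with a stated time of 6 min; a higher number here means a weaker inhibitor, a lower number a stronger inhibitor. Compound 1 `CCCCN(C)c1nc(C(C)(C)C)ccc1CNC(=O)C(C)c1ccc(NS(C)(=O)=O)c(F)c1` gives 1.2 nM. Within the data shown here, compound 2 `CCCCCCOc1nc(C(C)(C)C)ccc1CNC(=O)C(C)c1ccc(NS(C)(=O)=O)c(F)c1` gives 2.7 nM, the higher of the two numbers; the only measured step, a 2.3-fold higher number from compound 1 to compound 2 (0.35 log units; beyond the scatter), separates it from compound 1, which is its nearest neighbour.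

Compound 3 `CCCCCCSc1nc(C(C)(C)C)ccc1CNC(=O)C(C)c1ccc(NS(C)(=O)=O)c(F)c1` differs from compound 2 in one place: hexylsulfanyl in place of hexyloxy on an aromatic carbon. Among the measured compounds shown here, no measured step covers this exchange; the one step known, a 2.3-fold higher number from compound 1 to compound 2 (0.35 log units; beyond the scatter), concerns a different change at the same aromatic carbon and so gives only a weak guide to the size of effects at that position. On that basis the step of a 1.3-fold higher number from compound 2 to compound 3 (0.11 log units; within the scatter) is expected to be small, possibly within the scatter, with a slight lean toward a higher number. Compound 3 is accordingly estimated at 3.5 nM in this assay, with a range from 1.2 nM to 10 nM.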

Compound 3, inhibition constant: 1.5 nM
For compound 3 the middle estimate is 2.3-fold (0.37 log units) above the measured one, within the range that was stated.
By their numbers in this assay, from the lowest: compounds 1, 3 and 2 (each within the scatter of the next, the first and the last beyond it).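

In this assay the exchange of oxygen for sulfur on the hexyl chain gives a 1.8-fold lower number from compound 2 to compound 3 (0.26 log units; within the scatter) and so has no resolved effect at this aromatic carbon. Hexylsulfanyl also stays close to butyl(methyl)amino, with a 1.3-fold higher number from compound 1 to compound 3 (0.10 log units; within the scatter) as the step, so compound 3 falls within the scatter of both compound 1 and compound 2 even though those two lie beyond the scatter of each other. No measured evidence is available to explain these values.

From the compounds shown here alone, whether a shorter chain such as butylsulfanyl would leave the number within the scatter of compound 3 remains open. Also open, going by these compounds, is whether a carboxylic acid or a primary amine on this aromatic carbon would give a step beyond the scatter.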